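This account rests on a few compounds, and the source may have more. Where it says the series, first, only, none or still open, it means among the compounds named here.

Measured compounds in a functional assay on MCF7 cells (Homo sapiens) for cytotoxicity, read by MTT assay, with a stated time of 72 h; a higher number here means a weaker inhibitor, a lower number a stronger inhibitor:
Compound 1, `CCOc1ccccc1Nc1nc(SCc2ccc(C(F)(F)F)cc2)nc2ccccc12`, gives > 50000 nM, which is a limit of the assay.
Compound 2, `FC(F)(F)c1ccc(CSc2nc(Nc3cccc(C(F)(F)F)c3)c3ccccc3n2)cc1`, gives 15300 nM.
Compound 3, `FC(F)(F)c1ccc(CSc2nc(Nc3ccc(Cl)cc3)c3ccccc3n2)cc1`, gives 21500 nM.

Of the two actual numbers in this assay, compound 3 carries the higher figure, but its gap to compound 2, a 1.4-fold higher number from compound 2 to compound 3 (0.15 log units; within the scatter), lies within the scatter, so the two cannot be ranked. The value of compound 1 is a limit rather than a number (the limit of > 50000 nM in this assay, at which 1 of the 3 values shown sits).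

The unmeasured compound 4, `CCOc1ccc(Nc2nc(SCc3ccc(C(F)(F)F)cc3)nc3ccccc23)cc1`, differs from compound 3 by ethoxy in place of chloro on an aromatic carbon. Among the measured compounds shown here, no measured step changes exactly this group. For the measured compounds named here, the steps that bear on it are those that alter the same aryl ring on the nitrogen: an at least 2.3-fold lower number from compound 1 to compound 3 (0.36 log units; beyond the scatter), where 2-ethoxyphenyl gave way to 4-chlorophenyl, and an at least 3.2-fold lower number from compound 1 to compound 2 (0.51 log units; beyond the scatter). Going by the values given here, both run from the only ethoxy-bearing compound toward lower numbers, and that compound sits at the limit. Returning to an ethoxy group, now on the aromatic carbon para to a large group, is therefore expected to raise the number in this assay, though the placement differs from that in compound 1 and the size is uncertain. The step from compound 3 to compound 4 is estimated as a 1.8-fold higher number from compound 3 to compound 4 (0.25 log units; within the scatter). Compound 4 is thus expected to give 38000 nM, within a range of 15000 nM to 100000 nM, with a real chance that only a limit is reported.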

Compound 4, half-maximal inhibitory concentration: > 50000 nM
Compound 4 was reported as a limit; the forecaster's own chance of this, stated with the estimate: 40%; middle value at least 1.3-fold (0.11 log units) away from the limit.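

In this assay, ethoxy in place of chloro on an aromatic carbon, para to a large group, gives an at least 2.3-fold higher number from compound 3 to compound 4 (0.36 log units; beyond the scatter) and so shows that an ethoxy group can accompany a loss of measurable activity away from the placement in compound 1. The change from 3-(trifluoromethyl)phenyl to 4-ethoxyphenyl on the nitrogen points the same way with an at least 3.2-fold higher number from compound 2 to compound 4 (0.51 log units; beyond the scatter) and this step also lies beyond the scatter. Compound 4 is reported as a limit rather than a number, as is compound 1, so the step between these two cannot be read and the two placements of ethoxy cannot be ranked: the limit of > 50000 nM in this assay, at which 2 of the 4 values shown sit.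

Among these four compounds, both ethoxy compounds sit at the limit while the chloro and trifluoromethyl compounds give numbers, but it remains open whether this extends to other groups at the same place, such as methoxy, a hydroxyl or an amine. As far as these compounds go, it also remains open whether a longer chain such as propoxy would behave like ethoxy, and how far the true value of compound 4 lies past the limit.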